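Series notes: aryl swap at the chloro-bearing benzylidene

This account rests on a few compounds, and the source may have more. Where it says the series, first, only, none or still open, it means among the compounds named here.

Compound 1 `C=CCn1c(=O)/c(=C\c2cccc(Cl)c2)[nH]c(=O)/c1=C\c1ccccc1OC` is the reference point of this set. In a functional assay on A549 cells (Homo sapiens) for cytotoxicity, read by CCK-8 assay, with a stated time of 72 h (a higher number here means a weaker inhibitor, a lower number a stronger inhibitor), compound 1 gives 5200 nM, the lowest of the two numbers recorded so far. Compound 2 `C=CCn1c(=O)/c(=C\c2cccc(F)c2)[nH]c(=O)/c1=C\c1ccccc1OC` gives 19700 nM in this assay, and the step of a 3.8-fold higher number from compound 1 to compound 2 (0.58 log units; beyond the scatter) is modest but beyond the usual scatter. Compound 3 `C=CCn1c(=O)/c(=C\c2ccc(Cl)c(Cl)c2)[nH]c(=O)/c1=C\c1ccccc1OC` was reported as "not active" (no number reported) in this assay, without a number.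

Compound 4 `C=CCn1c(=O)/c(=C\c2ccc(C)cc2)[nH]c(=O)/c1=C\c1ccccc1OC` is the next member, not yet measured. The change from compound 1 is 4-methylphenyl in place of 3-chlorophenyl on a double-bonded chain carbon bound to an aromatic carbon. Among the compounds with values here, no measured step bears directly on this change: the only quantified step, from compound 1 to compound 2, exchanges one halogen for another on the same aryl group, and compound 3 adds a second chlorine rather than removing one. Both available data points, the weakening seen in a 3.8-fold higher number from compound 1 to compound 2 (0.58 log units; beyond the scatter) and the loss of activity in compound 3, indicate that this aryl group is sensitive to substitution, so a change that removes the chlorine altogether is expected to cost rather than gain potency. For compound 4 the estimated step is a 2.3-fold higher number from compound 1 to compound 4 (0.36 log units; beyond the scatter), with wide uncertainty. The expected value for compound 4 in this assay is 12000 nM, within an estimated range of 3500 nM to 45000 nM.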

Compound 4, half-maximal inhibitory concentration: "not active" (no number reported)
The entry for compound 4 holds no number; there is nothing to compare the estimate with.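

Within the data shown here, compound 4 is recorded as "not active" in this assay without a number, so no new step from compound 1 can be read. No available evidence bears on this result. The compounds shown leave open whether any group other than 3-chlorophenyl at this place on the shared core retains a measurable value.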